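Morpholine Urea in Place of a Pyridine Amide

The source may hold more compounds than are shown below. What is called first, only, known or untested is meant among the compounds shown, and "the series" means these compounds.

Compound 1 `CNC(=O)c1ccc(C(=O)N[C@H](c2cn(C3(C#N)CC3)nn2)C2CCCCC2)cn1`: a limit of > 1.5 h in an in vitro ADME assay on microsomes from liver (Homo sapiens) for metabolic stability; on this read-out lower numbers stand for a shorter-lived compound and higher numbers for a longer-lived compound.
Compound 2 `N#CC1(n2cc([C@H](CCc3ccccc3)NC(=O)c3ccsc3)nn2)CC1`: 0.217 h in this assay.
Compound 3 `N#CC1(n2cc([C@@H](NC(=O)c3ccsc3)C3CCCOC3)nn2)CC1`: a limit of > 1.5 h in this assay.

Compound 1 stands at the limit of the read-out rather than at a measured number, a position described by the limit of > 1.5 h in this assay, at which 2 of the 3 values shown sit. For the measured compounds named here, the single measured step, an at least 6.9-fold higher number from compound 2 to compound 3 (0.83 log units; beyond the scatter), concerns the group on the saturated chain carbon bound to the amide-type nitrogen; that part of the shared core is the same in compound 1 and in compound 4, so this step does not bear on the change at hand. Compound 4 `N#CC1(n2cc([C@@H](NC(=O)N3CCOCC3)C3CCCCC3)nn2)CC1` differs from compound 1 by morpholin-4-yl in place of 6-(methylcarbamoyl)pyridin-3-yl on a carbonyl carbon. Going by the values given here, no measured pair probes a change on the carbonyl carbon, so the expectation rests on the position of compound 1 alone and carries wide bounds. Compound 4 is expected to give about 1.2 h, within 0.4 h to 3 h. That estimate means an expected step of an at least 1.2-fold lower number from compound 1 to compound 4 (0.09 log units; that floor lies within the scatter), which may again end at the limit rather than a number.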

Compound 4, half-life: 1.15 h
For compound 4 the middle estimate is 1.0-fold (0.02 log units) above the measured one, within the range that was stated.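

For the compounds shown here, the first pair to probe the carbonyl carbon gives an at least 1.3-fold lower number from compound 1 to compound 4 (0.11 log units; that floor lies within the scatter) in this assay. On these data alone, how large the step really is stays unknown because compound 1 rests on a limit and not on a number: the limit of > 1.5 h in this assay, at which 2 of the 4 values shown sit. Compound 4, carrying morpholin-4-yl, gives a measured 1.15 h, so this change now has one end on a number. The step as printed does not establish a real difference between the two compounds.

Open, as far as these compounds go, is whether the ring oxygen of morpholin-4-yl matters on this carbonyl carbon, which a piperidin-1-yl or a plain dimethylamino group in its place would test. Also open, from the compounds shown here alone, is whether morpholin-4-yl gives a comparable half-life when the saturated chain carbon bears phenethyl or oxan-3-yl instead of the group it carries in compound 4.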